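Trifluoromethoxy in place of trifluoromethyl

A few compounds are considered here, and "the series" means these few. Any claim that something is new, unique, unknown or untested is made for them only; others in the source may bear on it.

Compound 1 `O=C(Nc1ccc(-c2cscn2)cc1)C1CCCN(Cc2cccc(F)c2)C1`: 2450 nM
Compound 2 `O=C(Nc1ccc(-c2cscn2)cc1)C1CCCN(Cc2cccc(C(F)(F)F)c2)C1`: > 20000 nM

In a functional assay on A-375 cells (Homo sapiens) for antiproliferative activity (a higher number here means a weaker inhibitor, a lower number a stronger inhibitor), compound 2 has only a limit of the assay, not a number: > 20000 nM. Compound 3 `O=C(Nc1ccc(-c2cscn2)cc1)C1CCCN(Cc2cccc(OC(F)(F)F)c2)C1` differs from it by one change: trifluoromethoxy in place of trifluoromethyl on an aromatic carbon. For the measured compounds named here, the single measured step, an at least 8.1-fold higher number from compound 1 to compound 2 (0.91 log units; beyond the scatter), lies beyond the scatter, but it replaces fluoro with trifluoromethyl and so bears only indirectly on this swap. Compound 3 is therefore expected to stay weak in this assay, close to compound 2, with no clear step in either direction. The expected change is an at least 1.1-fold lower number from compound 2 to compound 3 (0.04 log units; that floor lies within the scatter). For compound 3 the estimate is 18000 nM, with an expected range from 6000 nM to 40000 nM.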

Compound 3, half-maximal inhibitory concentration: > 20000 nM
Compound 3 gave a limit, no number (the forecaster's own chance of this, stated with the estimate: 50%); middle value at least 1.1-fold (0.04 log units) away from the limit.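

In this assay there is an at least 8.1-fold higher number from compound 1 to compound 3 (0.91 log units; beyond the scatter) with trifluoromethoxy in place of fluoro, so the loss seen with trifluoromethyl is not confined to that one group. Among the compounds shown, only fluoro at this place gives a readable number. The step from compound 2 to compound 3 cannot be read, because both compounds stand at a limit of the assay rather than at a number: the limit of > 20000 nM in this assay, at which 2 of the 3 values shown sit.

Still open, as far as these compounds go, is whether an amine or a carboxylic acid at this place on the ring would give a readable number. From the compounds shown here alone, how a plain methyl group would compare with fluoro also remains open.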